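Swapping the propargyl for a propenyl on sulfur

This account rests on a few compounds, and the source may have more. Where it says the series, first, only, none or still open, it means among the compounds named here.

Compound 1 `C#CCSc1nc(Nc2cccc(Cl)c2)c2ccncc2n1` gives 1090 nM in a functional assay on HepG2 cells (Homo sapiens) for inhibition, read by MTT assay, with a stated time of 72 h; on this read-out higher numbers stand for weaker inhibition and lower numbers for stronger inhibition. Compound 2 `C#CCSc1nc(Nc2cccc(OC)c2)c2ccncc2n1` gives 920 nM in this assay. Compound 3 `C#CCSc1nc(Nc2cccc(O)c2)c2ccncc2n1` gives 29500 nM in this assay.

Among the three, compound 2 holds the lowest number, but compound 1 sits within the scatter of it (a 1.2-fold lower number from compound 1 to compound 2 (0.07 log units; within the scatter)), so the two cannot be ranked. For the measured compounds named here, compound 3 lies well apart (a 32-fold higher number from compound 2 to compound 3 (1.51 log units; beyond the scatter), and from the chloro analogue a 27-fold higher number from compound 1 to compound 3 (1.43 log units; beyond the scatter)), which marks the only large step seen here.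

Compound 4 `C/C=C/Sc1nc(Nc2cccc(OC)c2)c2ccncc2n1` differs from compound 2 in one place: prop-1-en-1-yl in place of propargyl on a sulfur. None of the three measured steps touches this position; all of them alter the group on the aromatic ring while the propargylsulfanyl stays fixed. The data therefore give no direct guide to the size or direction of this change. Given an exchange of one three-carbon, ring-free chain for another of the same length and with the same count of donors and acceptors, compound 4 is expected to stay near compound 2, with an expected step of a 1.2-fold higher number from compound 2 to compound 4 (0.08 log units; within the scatter), not beyond the scatter. Compound 4 is estimated at 1100 nM, within a range of 350 nM to 4000 nM.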

Compound 4, half-maximal inhibitory concentration: 18100 nM
Compound 4: middle estimate off by 16-fold (1.22 log units), on the low side, and the stated range ends below it.
By their numbers in this assay, from the lowest: compounds 2 and 1 (each within the scatter of the next); then compounds 4 and 3 (each within the scatter of the next).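

In this assay, the group on sulfur proves to be a sensitive position: with the methoxy group and the shared core held fixed, prop-1-en-1-yl in place of propargyl gives a 20-fold higher number from compound 2 to compound 4 (1.29 log units; beyond the scatter). Until now, the only large steps came from the hydroxy change on the aromatic ring, so this is the first sign that the sulfur chain matters as well, and the step is large even though both chains match in their counts of heavy atoms, donors and acceptors and both lack a ring, leaving a triple bond against a double bond as the difference in the listed features. No measurement shown here accounts for the size of this step.

The compounds shown leave open whether the weaker result follows from losing the triple bond or is particular to prop-1-en-1-yl, and how an allyl, a propyl or a longer chain ending in a triple bond on the sulfur would read in this assay. They also leave open whether the same step would appear with chloro in place of methoxy on the aromatic ring.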